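A few compounds are considered here, and "the series" means these few. Any claim that something is new, unique, unknown or untested is made for them only; others in the source may bear on it.

Of the compounds shown here, three have been measured so far in an ADME assay on MDCKII-LE cells (Canis lupus familiaris) for permeability; a higher number here means that the compound crosses the layer faster, a lower number that the compound crosses the layer more slowly. Compound 1 (`Cc1cnc(NC(=O)c2cc(Oc3ncc(C(=O)N(C)C)cn3)c3cc(C)oc3c2)cn1`) gives 34.7 10^-6 cm/s and compound 2 (`Cc1cnc(NC(=O)c2cc(Oc3cnc(C(=O)N4CCCC4)cn3)c3cc(C)oc3c2)cn1`) gives 15.8 10^-6 cm/s in this read-out, while compound 3 (`Cc1cc2c(Oc3cnc(C(=O)N4CC(C)(C)C4)cn3)cc(C(=O)Nc3cnccn3)cc2o1`) gives 7.7 10^-6 cm/s and stands lowest of the three, beyond the scatter from both others. Compound 2 lies nearest to it and compound 1 furthest. Compound 4 (`Cc1cc2c(Oc3cnc(C(=O)N4CC(C)(O)C4)cn3)cc(C(=O)Nc3cnccn3)cc2o1`) differs from compound 3 in one place: hydroxy in place of methyl on a saturated ring carbon, which turns 3,3-dimethylazetidin-1-yl into 3-hydroxy-3-methylazetidin-1-yl. Among the compounds with values here, no two measured compounds differ in one place only, so the data hold no direct precedent for this change. A downward step beyond the scatter is nevertheless expected in this assay for this swap, as a judgement and not as a measured trend. The expected size is a 2.2-fold lower number from compound 3 to compound 4 (0.34 log units; beyond the scatter) and the true step could come close to the scatter. The estimated value for compound 4 is 3.5 10^-6 cm/s with an expected range from 1.5 10^-6 cm/s to 7 10^-6 cm/s in this assay.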

Compound 4, apparent permeability: 9 10^-6 cm/s
The estimate for compound 4 lay 2.6-fold (0.41 log units) below the measured number; the whole stated range lies below it.
By their numbers in this assay, from the lowest: compounds 3, 4 and 2 (each within the scatter of the next, the first and the last beyond it); then compound 1.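

In this assay, within the data shown here, hydroxy in place of methyl on a saturated ring carbon of the four-membered ring gives a 1.2-fold higher number from compound 3 to compound 4 (0.07 log units; within the scatter) and is the first single-place comparison. Turning 3,3-dimethylazetidin-1-yl into 3-hydroxy-3-methylazetidin-1-yl thus brings in one hydrogen-bond donor and one hydrogen-bond acceptor, yet the two compounds cannot be told apart in this read-out. No measurement at hand accounts for this result.

This remains a single pair on one core, so it cannot show whether the same swap would behave alike on another ring or amide. It also leaves open whether an amine, a carboxylic acid or a methoxy group on that ring carbon would stay equally within the scatter of the methyl compound.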